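The source may report more compounds than this note shows. Statements on the series, on what has been measured and on what is new or still open speak of the compounds shown alone.

Compound 2 `c1ccc(C(/N=C2\CCCCCN2)C2CCC2)cc1` sits at the bottom of the three measured numbers: in a functional assay on the whole organism (plasma, strain Sprague-Dawley) with Rattus norvegicus as the target, with a stated time of 2 h, at a dose of 100 mg/kg by the oral route (on this read-out lower numbers stand for a weaker effect and higher numbers for a stronger effect at the one dose given), compound 2 gives 44%, level at the digits shown with compound 3 `c1csc(C(/N=C2\CCCCCN2)C2CC2)c1`, which gives 44%. Compound 1 `Cc1ccc(C(/N=C2\CCCCCCCN2)C2CC2)c(C)c1` stands apart, giving 61%, beyond the scatter from compound 2.

Compound 4 `c1ccc(C(/N=C2\CCCCCN2)c2ccco2)cc1` has not yet been measured; it differs from compound 2 by furan-2-yl in place of cyclobutyl on a saturated chain carbon bound to an aromatic carbon and a double-bonded nitrogen. Among the compounds with values here, no single-change step among the measured compounds shows what such a swap does. Compounds 2 and 3 differ at two places yet give numbers within the scatter of each other, which is the only hint available. The expected step is no change at the digits printed from compound 2 to compound 4 (within the scatter), small and with no firm direction beyond the scatter. Compound 4 is estimated at 44%, within a range of 25% to 65%.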

Compound 4, a percentage reported as inhibition, in the whole organism at one dose (the size of the read-out at that dose, not a potency): 52%
For compound 4 the middle estimate is 8 percentage points below the measured one; low and high end bracket the measured number.
By their numbers in this assay, from the lowest: compounds 2, 3, 4 and 1 (each within the scatter of the next, the first and the last beyond it).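

In this assay, within the data shown here, the first single-change step puts furan-2-yl in place of cyclobutyl on a saturated chain carbon bound to an aromatic carbon and a double-bonded nitrogen, and gives a number 8 percentage points higher from compound 2 to compound 4 (within the scatter). At this position, a five-membered aromatic ring with a hydrogen-bond acceptor therefore stands in for a four-membered carbon ring without a step beyond the scatter. No measured property is available to explain this step.

On these data alone, whether phenyl, a dimethylamino group or a carboxylic acid at this position would give a step beyond the scatter remains open.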